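A Chloro Group Added to Compound 2

A few compounds are considered here, and "the series" means these few. Any claim that something is new, unique, unknown or untested is made for them only; others in the source may bear on it.

- compound 1 `COc1ccc(C2CC(c3ccccc3)=NN2C(=O)c2ccco2)cc1` > 50000 nM (a limit of the assay, not a number)
- compound 2 `COc1ccc(C2CC(c3ccccc3)=NN2C(=O)c2nc3ccccc3s2)cc1` 6300 nM

For the measured compounds named here, in a functional assay on BT-474 cells (Homo sapiens) for antiproliferative activity, read by CCK-8 assay, with a stated time of 72 h (a lower number here means a stronger inhibitor, a higher number a weaker inhibitor), compound 2 holds the only true number so far. Compound 1 has only a limit. Compound 3 `COc1ccc(C2CC(c3ccc(Cl)cc3)=NN2C(=O)c2nc3ccccc3s2)cc1` differs from compound 2 by one change on a phenyl ring (chloro in place of hydrogen on an aromatic carbon). Going by the values given here, the single measured step, an at least 7.9-fold lower number from compound 1 to compound 2 (0.89 log units; beyond the scatter), is sizeable, but it replaced the group on the carbonyl carbon and not this phenyl, so it offers little guidance here. From the compounds shown here alone, no step beyond the scatter is therefore expected, and the direction stays open. The estimate means an expected 1.3-fold lower number from compound 2 to compound 3 (0.10 log units; within the scatter) overall. Compound 3 is expected near 5000 nM (estimated range 1500 nM to 17000 nM) in this assay.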

Compound 3, half-maximal inhibitory concentration: 7200 nM
Compound 3: middle estimate off by 1.4-fold (0.16 log units), on the low side, within the range that was stated.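

In this assay, the change from phenyl to 4-chlorophenyl gives a 1.1-fold higher number from compound 2 to compound 3 (0.06 log units; within the scatter) and so produces no real difference. For the compounds shown here, the earlier step changed the group on the carbonyl carbon, whereas this one gives the first reading at the phenyl ring, showing that this position tolerates a chlorine atom with no measurable gain or loss. Nothing measured here bears on this result.

From the compounds shown here alone, whether an amine, a carboxylic acid or a longer chain at this position would shift the number beyond the scatter remains open.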